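Changing the Group on the Chain Carbon Once More

This account rests on a few compounds, and the source may have more. Where it says the series, first, only, none or still open, it means among the compounds named here.

Of the compounds shown here, three built on one shared core have been tested in a functional assay on MIA PaCa-2 cells (Homo sapiens) for inhibition, read by MTT assay, with a stated time of 72 h; on this read-out higher numbers stand for weaker inhibition of growth and lower numbers for stronger inhibition of growth. Compound 1 `O=S(=O)(NCCCNCc1cccc2ccccc12)c1cc(C(F)(F)F)cc(C(F)(F)F)c1` gives 2800 nM, compound 2 `CC(C)(C)c1ccc(CNCCCNS(=O)(=O)c2cc(C(F)(F)F)cc(C(F)(F)F)c2)cc1` gives 2300 nM, and compound 3 `O=S(=O)(NCCCNCc1cccc(Cl)c1)c1cc(C(F)(F)F)cc(C(F)(F)F)c1` gives 4400 nM. Compound 3 carries the highest of the three numbers, but it does not stand apart from the other two: a 1.6-fold higher number from compound 1 to compound 3 (0.20 log units; within the scatter) and a 1.9-fold higher number from compound 2 to compound 3 (0.28 log units; within the scatter), and the pair of compounds 1 and 2 also lie close together, since a 1.2-fold lower number from compound 1 to compound 2 (0.09 log units; within the scatter).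

Compound 4 `O=S(=O)(NCCCNCC1COc2ccccc2O1)c1cc(C(F)(F)F)cc(C(F)(F)F)c1` has not yet been measured. It differs from compound 3 in a single place, (2,3-dihydro-1,4-benzodioxin-2-yl in place of 3-chlorophenyl on a saturated chain carbon bound to an amine nitrogen). Only one position in the series has been varied so far, and it is this same saturated chain carbon bound to an amine nitrogen. The two steps that bear on the new change are those leading into compound 3, and neither of them moved the number beyond the scatter. On that basis no step beyond the scatter is expected in this assay; the estimated step is a 1.1-fold lower number from compound 3 to compound 4 (0.04 log units; within the scatter). Compound 4 is therefore expected to give about 4000 nM in this assay, within a range from 1800 nM to 9000 nM.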

Compound 4, concentration for 50% growth inhibition: 2600 nM
Compound 4: the middle estimate sits 1.5-fold (0.19 log units) above what was measured; the range from low to high includes it.
By their numbers in this assay, from the lowest: compounds 2, 4, 1 and 3 (each within the scatter of the next).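

With 2,3-dihydro-1,4-benzodioxin-2-yl, a group with a six-membered non-aromatic ring holding 2 hetero atoms and with 2 hydrogen-bond acceptors now sits on the saturated chain carbon bound to an amine nitrogen, and in this assay the step stays small, with a 1.7-fold lower number from compound 3 to compound 4 (0.23 log units; within the scatter). Measured against the two other groups, the change gives a 1.1-fold higher number from compound 2 to compound 4 (0.05 log units; within the scatter) and a 1.1-fold lower number from compound 1 to compound 4 (0.03 log units; within the scatter), so the tolerance of this position now extends beyond groups built only from aromatic carbon rings, and none of the four compounds stands apart from the others. No measurement is at hand that would account for these small steps or tie them to any feature of the entering group.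

Going by these compounds, what remains open is whether a carboxylic acid, an amine or a plain cyclohexyl group on the same chain carbon would move the number beyond the scatter. All four compounds share one core, so the compounds shown also leave open what a longer chain or an amide in place of the amine would do to growth inhibition in this assay.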